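Replacing 4-Fluorophenyl with 3-Nitrophenyl on a Shared Core

A few compounds are considered here, and "the series" means these few. Any claim that something is new, unique, unknown or untested is made for them only; others in the source may bear on it.

In a functional assay on K562 cells (Homo sapiens) for cytotoxicity, read by MTT assay, with a stated time of 24 h (a higher number here means a weaker inhibitor, a lower number a stronger inhibitor), compound 1 `COc1cc(/C=C2\CN(C)C/C(=C\c3ccccc3F)C2=O)cc(OC)c1` gives 6320 nM, compound 2 `COc1cc(/C=C2\CN(C)C/C(=C\c3ccc(F)cc3)C2=O)cc(OC)c1` gives 11300 nM and compound 3 `COc1cc(/C=C2\CN(C)C/C(=C\c3ccc(F)cc3)C2=O)cc(OC)c1OC` gives 10300 nM. These three numbers all lie within the scatter of one another, so compound 3 holds no rank apart from the other two.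

Compound 4 `COc1cc(/C=C2\CN(C)C/C(=C\c3cccc([N+](=O)[O-])c3)C2=O)cc(OC)c1OC` differs from compound 3 at a single place, on a double-bonded chain carbon bound to a double-bonded ring carbon, where 3-nitrophenyl stands in place of 4-fluorophenyl: 3-nitrophenyl in place of 4-fluorophenyl on a double-bonded chain carbon bound to a double-bonded ring carbon.

The closest evidence is a change at that same place, 4-fluorophenyl in place of 2-fluorophenyl, which gave a 1.8-fold higher number from compound 1 to compound 2 (0.25 log units; within the scatter). A different change, methoxy in place of hydrogen on an aromatic carbon, gave a 1.1-fold lower number from compound 2 to compound 3 (0.04 log units; within the scatter). Neither step goes beyond the scatter. Among the compounds with values here, no measured compound carries 3-nitrophenyl, however, so these two steps offer only weak guidance for the new group.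

A step beyond the scatter is therefore not expected in this assay, and no firm direction can be assigned. The estimated step is a 1.2-fold lower number from compound 3 to compound 4 (0.08 log units; within the scatter). The estimate for compound 4 is 8500 nM, with an expected range from 3500 nM to 20000 nM.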

Compound 4, half-maximal inhibitory concentration: 4200 nM
Compound 4: middle estimate off by 2.0-fold (0.31 log units), on the high side; the range from low to high includes it.
By their numbers in this assay, from the lowest: compounds 4, 1, 3 and 2 (each within the scatter of the next, the first and the last beyond it).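

In this assay, 3-nitrophenyl in place of 4-fluorophenyl on a double-bonded chain carbon bound to a double-bonded ring carbon gave a 2.5-fold lower number from compound 3 to compound 4 (0.39 log units; beyond the scatter), the only step shown here that passes beyond the scatter. Within the data shown here, the earlier change at this same place, from 2-fluorophenyl to 4-fluorophenyl, and the added methoxy both stayed within the scatter, so the new step is the first sign in these compounds that the group at this place can move the number, though only modestly. Nothing measured here accounts for the shift, so it cannot be tied to any feature of the entering or leaving group.

As far as these compounds go, it remains open whether the shift belongs to the nitro group itself or would also appear with other groups at this place, such as 4-nitrophenyl, 3-aminophenyl or 3-cyanophenyl. From the compounds shown here alone, it is equally open whether 3-nitrophenyl would give a step of similar size on the core of compound 2, which has one methoxy fewer than compound 3, or whether the step depends on that added methoxy.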